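The source may report more compounds than this note shows. Statements on the series, on what has been measured and on what is new or still open speak of the compounds shown alone.

Two compounds share one core and differ only in where a chloro sits on the nitro-bearing ring. Compound 1 `O=[N+]([O-])c1cc(Cl)ccc1CNc1cc(C(F)(F)F)cc2[nH]ncc12` and compound 2 `O=[N+]([O-])c1ccc(Cl)cc1CNc1cc(C(F)(F)F)cc2[nH]ncc12` were both tested in an assay for inhibition of Tryptophan 2,3-dioxygenase (Homo sapiens), with stated times of 10 min and 60 min, tested at 100 uM; a higher number here means a stronger effect of the compound at the concentration tested, a lower number a weaker effect. In this assay compound 1 gives 93%, and compound 2 gives 88%. For the measured compounds named here, these are the only two numbers known so far, and the two values lie within the usual scatter of one another, so nothing separates compound 2 from compound 1 on the evidence at hand.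

The next compound, compound 3 `O=[N+]([O-])c1ccccc1CNc1cc(C(F)(F)F)cc2[nH]ncc12`, follows from compound 2 by a single change: hydrogen in place of chloro on an aromatic carbon. Going by the values given here, no pair of measured compounds shows what this kind of change does here, so the size of the step is open. Because both compound 1 at 93% and compound 2 at 88% sit high with the chloro in either place, the shared core with its nitro group and trifluoromethyl appears to carry most of the effect, and compound 3 is expected to stay close to compound 2, with a step estimated at a number 4 percentage points lower from compound 2 to compound 3 (within the scatter), none beyond the scatter or a modest fall. Compound 3 is therefore expected to give about 84%, within a range from 65% to 96%.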

Compound 3, a percentage reported as inhibition, at one concentration (the size of the read-out at that concentration, not a potency): 95%
Estimate against measurement, compound 3: 11 percentage points below; the measured number falls inside the stated range.
By their numbers in this assay, from the lowest: compounds 2, 1 and 3 (each within the scatter of the next).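

In this assay, putting hydrogen in place of the chloro that sits para to a nitro group gives a number 7 percentage points higher from compound 2 to compound 3 (within the scatter), and the same swap for the chloro of compound 1 gives a number 2 percentage points higher from compound 1 to compound 3 (within the scatter). Neither step goes beyond the scatter, so a chloro on this ring is not required for a high read-out at the tested concentration, and neither of its two places can be told apart from having no chloro at all. For the compounds shown here, nothing measured so far offers an explanation for this result.

A single-concentration percentage shows the size of the effect at that concentration and not a potency, so any real differences in potency among these three compounds remain hidden, and a full concentration series would be needed to reveal them. Going by these compounds, it also remains open whether the ring accepts groups other than chloro and hydrogen at this place, such as a methoxy group, an amine or a carboxylic acid, and what happens when the nitro group itself is exchanged for a nitrile or an amine.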